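Swapping chlorine for a methyl group: expected cytotoxicity

The source may report more compounds than this note shows. Statements on the series, on what has been measured and on what is new or still open speak of the compounds shown alone.

In an ADME assay on cells (T-cell, Mus musculus, strain BALB/c) for cytotoxicity, read by MTT assay, with a stated time of 48 h (on this read-out lower numbers stand for higher toxicity in this test and higher numbers for lower toxicity in this test), three compounds have been measured:
Compound 1 `COC(=O)c1c(F)cccc1OC(=O)COc1cc(O)c2c(=O)cc(-c3ccccc3)oc2c1`: 319000 nM
Compound 2 `COC(=O)c1cc(Cl)ccc1OC(=O)COc1cc(O)c2c(=O)cc(-c3ccccc3)oc2c1`: > 436000 nM
Compound 3 `C=C(CCc1cc(O)c2c(=O)cc(-c3ccccc3)oc2c1)Cc1c(Br)cccc1C(=O)CC` gives 379000 nM.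

For compound 2 the assay reports only the limit of > 436000 nM in this assay, at which 1 of the 3 values shown sits, and no number. Among the compounds with values here, the one measured step that involves compound 2 is an at least 1.3-fold higher number from compound 1 to compound 2 (0.13 log units; that floor lies within the scatter), a floor that lies within the scatter. Compound 4 `COC(=O)c1ccc(C)cc1OC(=O)COc1cc(O)c2c(=O)cc(-c3ccccc3)oc2c1` differs from compound 2 in one place: a group of 11 heavy atoms (9 carbon, 2 oxygen; one six-membered aromatic ring of carbon only) in place of a group of 11 heavy atoms (8 carbon, 2 oxygen, 1 chlorine; one six-membered aromatic ring of carbon only), on an oxygen next to a carbonyl group. Within the data shown here, no measured pair isolates this kind of exchange, and the single step around compound 2 shows no shift beyond the scatter. The step from compound 2 to compound 4 is therefore expected to be an at least 1.0-fold lower number from compound 2 to compound 4 (0.03 log units; that floor lies within the scatter). Compound 4 is estimated at 400000 nM, in a range from 220000 nM to 700000 nM.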

Compound 4, half-maximal cytotoxic concentration: 250000 nM
Estimate against measurement, compound 4: 1.6-fold (0.20 log units) above; the range from low to high includes it.
By their numbers in this assay, from the lowest: compounds 4, 1 and 3 (each within the scatter of the next). At a limit, above all of these: compound 2.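

With compound 4, a group without halogen now sits on this oxygen next to a carbonyl group, and it gives an at least 1.7-fold lower number from compound 2 to compound 4 (0.24 log units; that floor lies within the scatter) and a 1.3-fold lower number from compound 1 to compound 4 (0.11 log units; within the scatter). Removing the halogen therefore produces no shift shown to lie beyond the scatter in either comparison. Compound 2 has only a limit, so its true distance from compound 4 stays unknown: the limit of > 436000 nM in this assay, at which 1 of the 4 values shown sits.

On these data alone, whether an amine or a carboxylic acid on this ring would move the number beyond the scatter remains open. So does the effect of a longer chain in place of the methoxycarbonyl group.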